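Working notes: compound 3 against compound 2

This account rests on a few compounds, and the source may have more. Where it says the series, first, only, none or still open, it means among the compounds named here.

Measured in a functional assay on A549 cells (Homo sapiens) for cytotoxicity, read by MTT assay, with a stated time of 48 h; on this read-out lower numbers stand for stronger inhibition and higher numbers for weaker inhibition:
Compound 1 `COc1ccc(-c2nc3ccccn3c2C(=O)/C=C\Nc2cc(OC)cc(OC)c2)cc1`: 4470 nM
Compound 2 `COc1cc(N/C=C\C(=O)c2c(-c3ccc(Cl)cc3)nc3ccccn23)cc(OC)c1OC`: 1140 nM

Of the two measured compounds, compound 2 has the lower number at 1140 nM, and the gap to compound 1 lies beyond the usual scatter. These two differ in more than one place, so their gap cannot be assigned to any single change.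

Compound 3 `COc1cc(N/C=C\C(=O)c2c(-c3ccc(Cl)cc3)nc3ccccn23)cc(OC)c1` departs from compound 2 in one place: hydrogen in place of methoxy on an aromatic carbon, para to a large group and ortho to two methoxy groups (hydrogen in place of methoxy on an aromatic carbon). Among the measured compounds shown here, no measured pair isolates this change, so the expectation rests on thin evidence. Compound 1 also carries hydrogen at that place and gives 4470 nM, which points cautiously towards a higher number in this assay, with a moderate step that may only just clear the scatter. The estimated step is a 2.0-fold higher number from compound 2 to compound 3 (0.30 log units; within the scatter). For compound 3 the expected value is 2300 nM, with an estimated range of 900 nM to 6000 nM.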

Compound 3, half-maximal inhibitory concentration: 9900 nM
For compound 3 the middle estimate is 4.3-fold (0.63 log units) below the measured one; measured number outside the range, above it.
By their numbers in this assay, from the lowest: compound 2; then compound 1; then compound 3.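

In this assay, hydrogen in place of methoxy on the aromatic carbon ortho to two methoxy groups and para to a large group gives an 8.7-fold higher number from compound 2 to compound 3 (0.94 log units; beyond the scatter). Among the compounds shown here, this is the first single change at this position that can be read on its own, and the step lies beyond the scatter, so the methoxy there matters, at least with chloro held constant. With hydrogen held at that place, chloro in place of methoxy on an aromatic carbon gives a 2.2-fold higher number from compound 1 to compound 3 (0.35 log units; beyond the scatter), also beyond the scatter, so the chloro of compound 3 does not bring a lower number in this setting, and no measurement at hand bears on the reason for either step.

The chloro step is read only with hydrogen at the first position, so the compounds shown leave open whether it keeps its direction and size when the methoxy is present. They also leave open whether an ethoxy, a hydroxyl or an amine on that same carbon would hold the lower number of compound 2 or lose it as hydrogen does.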